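The compounds below may be only part of what the source reports. "The series", "measured", "known", "first", "only" and "open" are said of these compounds alone.

Measured compounds in a functional assay on A549 cells (Homo sapiens) for antiproliferative activity, read by MTT assay, with a stated time of 48 h; on this read-out lower numbers stand for stronger inhibition and higher numbers for weaker inhibition:
compound 1, `CC(=O)Nc1ccc(-n2nncc2CN2C(=O)C3(C(C#N)=C(N)Oc4c3c3nc5ccccc5nc3c3ccccc43)c3ccccc32)cc1`; compound 1 gives only an assay limit, > 50000 nM.
compound 2, `Cc1ccc(Cl)cc1-n1nncc1CN1C(=O)C2(C(C#N)=C(N)Oc3c2c2nc4ccccc4nc2c2ccccc32)c2ccccc21`; compound 2 gives only an assay limit, > 50000 nM.
compound 3, `N#CC1=C(N)Oc2c(N)cc3nc4ccccc4nc3c2C12C(=O)N(Cc1cnnn1-c1ccc(Cl)cc1)c1ccccc12`; compound 3 gives only an assay limit, > 50000 nM.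

All three values sit at the limit of > 50000 nM in this assay, at which 3 of the 3 values shown sit, so none of them is a number. Among the compounds with values here, the only step between compounds that differ in one place, a step that the two limits leave unreadable from compound 1 to compound 2, has a limit at both ends and so yields no size and no direction. Compound 3 therefore stands at the limit of this assay, with no measured number anywhere in the set to place it against.

Compound 4, `N#CC1=C(N)Oc2c(N)cc3nc4ccccc4nc3c2C12C(=O)N(Cc1cnnn1-c1cc(Cl)ccc1Cl)c1ccccc12`, differs from compound 3 by 2,5-dichlorophenyl in place of 4-chlorophenyl on an aromatic nitrogen. Within the data shown here, no measured pair differs by this exchange, and the single measured step is unreadable, so nothing in the data gives a size or direction for it. With compound 3 at the limit, compound 4 is expected to remain at the limit as well. Compound 4 is thus estimated at 50000 nM in this assay, within 20000 nM to 200000 nM. The step this estimate means, a number no higher from compound 3 to compound 4 (the limit leaves the size open), is expected to be none beyond the scatter.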

Compound 4, half-maximal inhibitory concentration: 10900 nM
Beside the measured number, compound 4's estimate is 4.6-fold (0.66 log units) above it, and the stated range ends above it.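

In this assay, the aromatic nitrogen of the five-membered ring with 3 nitrogen is now a place where a change can be read: 2,5-dichlorophenyl in place of 4-chlorophenyl gives an at least 4.5-fold lower number from compound 3 to compound 4 (0.66 log units; beyond the scatter). Within the data shown here, the earlier step at this nitrogen, between compound 1 and compound 2, cannot be read, so this is the first sign that the aryl group here affects the read-out. Compound 4 is the only compound shown with a number, and the others remain limits, not numbers: the limit of > 50000 nM in this assay, at which 3 of the 4 values shown sit.

This single pair does not show whether the second chlorine alone accounts for the step, or how a plain phenyl or a methoxyphenyl on the same nitrogen would read. Also open, as far as these compounds go, is whether 2,5-dichlorophenyl would give a number on the core of compound 1.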